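Half-life notes on a small brominated amide series

A few compounds are considered here, and "the series" means these few. Any claim that something is new, unique, unknown or untested is made for them only; others in the source may bear on it.

Measured so far:
- compound 1, `CCc1nc2ccc(Cl)cn2c1C(=O)NCCOc1ccc(N(C)C)cc1`: 2.7 h
- compound 2, `CCc1nc2ccc(Br)cn2c1C(=O)NCCOc1ccc(N2CCCCC2)cc1`: 4.19 h

Two compounds have numbers in an ADME assay on the whole organism (Mus musculus, strain ICR) for metabolic stability, read by HPLC, with a stated time of 24 h, at a dose of 50 mg/kg by the oral route; a lower number here means that the compound disappears faster, a higher number that the compound lasts longer. Compound 1 gives 2.7 h there. Compound 2 gives the higher of the two numbers, 4.19 h, but its gap to compound 1 lies within the scatter of repeated measurements, so the two values read as comparable rather than ordered. Within the data shown here, no step between measured compounds that differ in one place exists, so no measured step is available to lean on.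

The next compound to be measured is compound 3, `CCc1nc2ccc(Br)cn2c1C(=O)NCCOc1ccc(N2CCC(C(F)(F)F)CC2)cc1`. It differs from compound 2 in one place: trifluoromethyl in place of hydrogen on a saturated ring carbon. Cut one bond further out, the change reads piperidin-1-yl to 4-(trifluoromethyl)piperidin-1-yl.

Among the measured compounds shown here, with no measured step of this kind and only two compounds within the scatter of each other, the expectation for this assay is a step from compound 2 to compound 3 of no clear direction and not beyond the usual scatter, a 1.1-fold higher number from compound 2 to compound 3 (0.03 log units; within the scatter). On that basis compound 3 is estimated at 4.5 h, with a range from 2.3 h to 8.5 h.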

Compound 3, half-life: 4.71 h
For compound 3 the middle estimate is 1.0-fold (0.02 log units) below the measured one; the range from low to high includes it.
By their numbers in this assay, from the lowest: compounds 1, 2 and 3 (each within the scatter of the next).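

In this assay, among these compounds, the step from hydrogen to trifluoromethyl on a saturated ring carbon, three ring bonds from the ring nitrogen, is the first single-place comparison, and it reads a 1.1-fold higher number from compound 2 to compound 3 (0.05 log units; within the scatter). Compound 2 and compound 3 are therefore comparable, and in this one pair the piperidin-1-yl to 4-(trifluoromethyl)piperidin-1-yl change leaves the half-life indistinguishable within the scatter of repeated measurements, which the earlier pair, differing in more than one place, could not show for any single position. No independent measurement accompanies this pair, so nothing here explains the reading.

This single step says nothing about how other groups behave on the same ring carbon: a hydroxyl, a carboxylic acid, an amine or a longer chain there could give a different reading. As far as these compounds go, it also remains open whether trifluoromethyl at this position would read the same on the core of compound 1, or whether a half-life clearly beyond the scatter can be reached by any change at this ring carbon.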